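From a Ring Amine to a Free Amine

This account rests on a few compounds, and the source may have more. Where it says the series, first, only, none or still open, it means among the compounds named here.

Compound 1 `Cn1cnc(S(=O)(=O)NCCOc2ccc3c(c2)[C@@H](Cc2cccc(Cl)c2)[C@@H](N)CC3)c1` gives 1.5 nM in an assay on cells for displacement of a labelled ligand from sodium- and chloride-dependent glycine transporter 1 (Homo sapiens), read by scintillation counting, with a stated time of 1 h; on this read-out higher numbers stand for weaker inhibition and lower numbers for stronger inhibition.
Compound 2 `Cn1cnc(S(=O)(=O)NCCOc2ccc3c(c2)[C@@H](Cc2cc(F)cc(Cl)c2)[C@@H](N)CC3)c1` gives 1.2 nM in this assay.
Compound 3 `Cn1cnc(S(=O)(=O)NCCOc2ccc3c(c2)[C@@H](Cc2ccccc2)[C@@H](N2CCCC2)CC3)c1` gives 1.2 nM in this assay.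

All three numbers sit close together. For the measured compounds named here, the only step between compounds that differ in a single place, a 1.3-fold lower number from compound 1 to compound 2 (0.10 log units; within the scatter), swaps a hydrogen on the benzyl ring for fluorine and does not move the number beyond the scatter. Compound 3 stands level with compound 2 at the digits shown and within the scatter of compound 1, so none of the three can be called the strongest.

Compound 4 `Cn1cnc(S(=O)(=O)NCCOc2ccc3c(c2)[C@@H](Cc2ccccc2)[C@@H](N)CC3)c1` differs from compound 3 in one place: amino in place of pyrrolidin-1-yl on a saturated ring carbon. Going by the values given here, no measured step touches this position; the fluorine step says nothing directly about the amine. Compound 1 and compound 2, which both carry the free amino group, give numbers level with compound 3, so the swap is expected to leave this assay within the scatter, a 1.3-fold higher number from compound 3 to compound 4 (0.10 log units; within the scatter). Compound 4 is therefore expected to give 1.5 nM, with a range from 0.5 nM to 5 nM.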

Compound 4, inhibition constant: 3.6 nM
Compound 4: middle estimate off by 2.4-fold (0.38 log units), on the low side, within the range that was stated.
By their numbers in this assay, from the lowest: compounds 2, 3 and 1 (each within the scatter of the next); then compound 4.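

For the compounds shown here, the first measured change at this saturated ring carbon, in this assay, is a 3.0-fold higher number from compound 3 to compound 4 (0.48 log units; beyond the scatter), so amino and pyrrolidin-1-yl are not interchangeable here when the benzyl ring carries no halogen. With the amino group kept, halogens on that ring also matter: a 2.4-fold higher number from compound 1 to compound 4 (0.38 log units; beyond the scatter) with hydrogen in place of chloro, and a 3.0-fold higher number from compound 2 to compound 4 (0.48 log units; beyond the scatter) with phenyl in place of 3-chloro-5-fluorophenyl. The level numbers of compound 1, compound 2 and compound 3 therefore hid two separate effects, and nothing available explains why either change moves the number.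

Going by these compounds, it remains open whether pyrrolidin-1-yl would give a similar step on the 3-chloro-5-fluorophenyl compounds. On these data alone, whether a dimethylamino group or a piperidine ring at this carbon would stand with compound 3 or with compound 4 also remains open.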